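The compounds below may be only part of what the source reports. "The series", "measured", "known", "first", "only" and "open" are said of these compounds alone.

Compound 1 `Cc1ccccc1CNc1nc(N)nc(-c2ccccc2CO)n1`: 4.7 in a functional assay on cells for positive allosteric modulation of G-protein coupled receptor 68 (Homo sapiens), read by a luciferase reporter and cAMP accumulation, with a stated time of 30 min, at pH 6.8 and pH 8.3, in the presence of a further agent that is not named here; on this read-out lower numbers stand for lower potency and higher numbers for higher potency (the scale is a negative logarithm)
Compound 2 `Cc1cccc(CNc2nc(N)nc(-c3ccccc3CO)n2)c1`: 4.4
Compound 3 `COc1ccc(CNc2nc(N)nc(-c3ccccc3CO)n2)cc1`: 3.34

Among these three, compound 2 stands second highest; its nearest neighbour is compound 1, whose step a number 0.30 log units lower from compound 1 to compound 2 (within the scatter) lies within the scatter, while the step of a number 1.06 log units lower from compound 2 to compound 3 (beyond the scatter) is large and beyond it. Compound 4 `Cc1cccc(CNc2nc(N)nc(-c3c(F)cccc3CO)n2)c1` keeps the core of compound 2 and differs only by fluoro in place of hydrogen on an aromatic carbon. Going by the values given here, none of the measured steps touches that ring: all three, including a number 1.36 log units lower from compound 1 to compound 3 (beyond the scatter), swap the aryl group on the saturated chain carbon bound to the ring nitrogen. Among the compounds with values here, no measured step therefore bears directly on this change, and a step of no size beyond the scatter in this assay is expected, namely no change at the digits printed from compound 2 to compound 4 (within the scatter). For compound 4 the estimated value is 4.4, within a range from 3.7 to 5.1.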

Compound 4, negative logarithm of the antagonist equilibrium constant: 4.44
For compound 4 the middle estimate is 0.04 log units below the measured one; measured number inside the range.
By their numbers in this assay, from the lowest: compound 3; then compounds 2, 4 and 1 (each within the scatter of the next).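

In this assay, fluoro in place of hydrogen on this aromatic carbon, ortho to a large group and meta to a hydroxymethyl group, gives a number 0.04 log units higher from compound 2 to compound 4 (within the scatter) and so leaves the number unmoved beyond the usual scatter. Going by these compounds alone, this is the first reading on this ring, since the earlier steps all swapped the aryl group on the saturated chain carbon. No measurement here offers an explanation for this result. Still open, on these data alone, is whether a chlorine atom or an amine on this same carbon would leave the number equally unmoved.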